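A few compounds are considered here, and "the series" means these few. Any claim that something is new, unique, unknown or untested is made for them only; others in the source may bear on it.

In a functional assay on CHO cells with adenosine receptor A1 (Homo sapiens) as the target, read by cAMP accumulation and immunoassay, with a stated time of 6 min, tested at 1 uM (on this read-out lower numbers stand for a stronger effect and higher numbers for a weaker effect at the one concentration tested), compound 2 `Nc1scc(CN2CCN(c3cccnc3)CC2)c1C(=O)c1ccc(Cl)cc1` gives -2.7%, the second highest of the three numbers measured. Compound 1 `CC(C)N1CCN(Cc2csc(N)c2C(=O)c2ccc(Cl)cc2)CC1` gives 7.3%, and the step of a number 10 percentage points lower from compound 1 to compound 2 (within the scatter) lies within the scatter. Among the compounds with values here, compound 3 `Nc1scc(CN2CCN(c3ccc(C(F)(F)F)cc3)CC2)c1C(=O)c1cccc(C(F)(F)F)c1` gives -27%, a number beyond the scatter below compound 2, but compound 3 differs from compound 2 in two places, so its value alone carries no step. Compound 4 `Nc1scc(CN2CCN(c3c(F)cccc3F)CC2)c1C(=O)c1ccc(Cl)cc1` differs from compound 2 by 2,6-difluorophenyl in place of pyridin-3-yl on an amine nitrogen in a ring. Within the data shown here, the only measured step at this ring nitrogen, from isopropyl to pyridin-3-yl, was within the scatter, so a step of about a number 3.3 percentage points lower from compound 2 to compound 4 (within the scatter) is expected, with no confident direction. Compound 4 is therefore estimated at -6%, within -26% to 14%.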

Compound 4, a percentage reported as activity, at one concentration (the size of the read-out at that concentration, not a potency): -65%
Beside the measured number, compound 4's estimate is 59 percentage points above it, and the stated range ends above it.
By their numbers in this assay, from the lowest: compound 4; then compound 3; then compounds 2 and 1 (each within the scatter of the next).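

In this assay replacing pyridin-3-yl with 2,6-difluorophenyl on the ring nitrogen gives a number 62.3 percentage points lower from compound 2 to compound 4 (beyond the scatter) and replacing isopropyl there gives a number 72.3 percentage points lower from compound 1 to compound 4 (beyond the scatter) as a second large step. The earlier step at this nitrogen stayed within the scatter, so only now does this position prove able to move the read-out strongly. Nothing available here explains the size of these steps. Still open, from the compounds shown here alone, is whether the two fluorines or the carbon-only ring carry the change, which a plain phenyl or a 2-fluorophenyl group on this nitrogen could separate.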